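This account rests on a few compounds, and the source may have more. Where it says the series, first, only, none or still open, it means among the compounds named here.

The series rests on a shared core carrying a 3-hydroxyphenyl group and a 2-hydroxyphenyl group, with a third aromatic group varied. In an assay on isolated protein for inhibition of DNA topoisomerase 1 (Homo sapiens), with a stated time of 30 min, tested at 100 uM (on this read-out lower numbers stand for a weaker effect and higher numbers for a stronger effect at the one concentration tested), compound 1 `Oc1cccc(-c2cc(-c3ccoc3)cc(-c3ccccc3O)n2)c1` gives 29.5%, and compound 2 `Oc1cccc(-c2cc(-c3ccccn3)cc(-c3ccccc3O)n2)c1` gives 35.4%. The only step shown, a number 5.9 percentage points higher from compound 1 to compound 2 (within the scatter), does not separate the two, so compound 2 stands alongside compound 1 within the scatter of this assay.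

Compound 3 `Oc1cccc(-c2cc(-c3cccnc3)cc(-c3ccccc3O)n2)c1` differs from compound 2 as follows: pyridin-3-yl in place of pyridin-2-yl on an aromatic carbon.

Among the compounds with values here, the one step that bears on this change, a number 5.9 percentage points higher from compound 1 to compound 2 (within the scatter), exchanged a different aromatic group at the same place and stayed within the scatter; it gives no sign that the third aromatic group moves this assay much. The step from compound 2 to compound 3 is therefore expected to be a number 2.4 percentage points lower from compound 2 to compound 3 (within the scatter), none beyond the scatter. Compound 3 is estimated at 33% in this assay, with a range from 18% to 48%.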

Compound 3, a percentage reported as inhibition, at one concentration (the size of the read-out at that concentration, not a potency): 1.9%
Compound 3: middle estimate off by 31.1 percentage points, on the high side; measured number below the stated range.
By their numbers in this assay, from the lowest: compound 3; then compounds 1 and 2 (each within the scatter of the next).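

In this assay, the result shows that this place, opposite the ring nitrogen, is sensitive to the third aromatic group: pyridin-3-yl in place of pyridin-2-yl, two groups with the same atoms and the same counts of donors and acceptors, gives a number 33.5 percentage points lower from compound 2 to compound 3 (beyond the scatter) on the shared core. Set against furan-3-yl, pyridin-3-yl gives a number 27.6 percentage points lower from compound 1 to compound 3 (beyond the scatter), so it stands apart from both other groups, while those two remain within the scatter of each other. Nothing available here accounts for this difference.

The compounds shown leave open how pyridin-4-yl, phenyl or an aminomethyl group would read at this place. They also leave open whether the same change would give a similar step with the 2-hydroxyphenyl group or the 3-hydroxyphenyl group replaced by an unsubstituted phenyl.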